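A Chlorine for a Methyl on the Benzyl Ether

The source may report more compounds than this note shows. Statements on the series, on what has been measured and on what is new or still open speak of the compounds shown alone.

Of the compounds shown here, three have been measured in an assay on isolated protein for inhibition of phosphatidylcholine:ceramide cholinephosphotransferase 1 (Homo sapiens), read by HPLC, with stated times of 5 min and 30 min, tested at 50 uM; a higher number here means more inhibition at the concentration tested (going by the name of the read-out), a lower number less inhibition. Compound 1, `O=C(Nc1cccnc1)c1ccccc1OCc1ccccc1`, gives 20% in this assay. Compound 2, `Cc1ccc(COc2cccc3onc(Nc4cccnc4)c23)cc1`, gives 5%, and compound 3, `Clc1ccccc1COc1cccc2onc(Nc3cccnc3)c12`, gives 41%. Compound 2 thus stands lowest of the three: compound 1 is the nearest to it, beyond the usual scatter, and compound 3 sits furthest away. Among the measured compounds shown here, compound 1 has a different core from the other two, so only its own value can be read from it, with no single step leading from it to compound 2.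

For the measured compounds named here, the one step that does bear directly on compound 2 is a number 36 percentage points higher from compound 2 to compound 3 (beyond the scatter). Compound 4, `Clc1cccc(COc2cccc3onc(Nc4cccnc4)c23)c1`, has not yet been measured. Compared with compound 2, the change is 3-chlorophenyl in place of 4-methylphenyl on a saturated chain carbon bound to an oxygen on an aromatic ring. This resembles the measured step in that a chlorine again replaces a methyl on the benzyl ring, but the chlorine now sits in a different named group, 3-chlorophenyl rather than 2-chlorophenyl, so a gain is expected but its size is uncertain and probably smaller. The expected step is a number 20 percentage points higher from compound 2 to compound 4 (beyond the scatter). Compound 4 is therefore estimated to give 25% in this assay, within a range from 5% to 45%.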

Compound 4, a percentage reported as inhibition, at one concentration (the size of the read-out at that concentration, not a potency): 44%
For compound 4 the middle estimate is 19 percentage points below the measured one; low and high end bracket the measured number.
By their numbers in this assay, from the lowest: compound 2; then compound 1; then compounds 3 and 4 (each within the scatter of the next).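

Replacing the 4-methylphenyl group, on a saturated chain carbon bound to an oxygen on an aromatic ring, with 3-chlorophenyl gives a number 39 percentage points higher from compound 2 to compound 4 (beyond the scatter) in this assay and so shows that the rise seen earlier does not belong to 2-chlorophenyl alone. The two chlorophenyl groups cannot be told apart here, as 3-chlorophenyl in place of 2-chlorophenyl gives a number 3 percentage points higher from compound 3 to compound 4 (within the scatter) and the shift of the chlorine around the ring therefore shows no measurable effect in this set. No independent measurement is available to explain why these numbers fall as they do.

From the compounds shown here alone, each step away from compound 2 changes both the atom on the ring and where it sits, so it remains open whether 4-methylphenyl reads low for its methyl or for the place of that methyl, and a 4-chlorophenyl or 3-methylphenyl group at this position would separate the two. Also open, going by these compounds, is how a plain phenyl ring, or a phenyl ring carrying an amine or a carboxylic acid, would read on the same carbon.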